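A few compounds are considered here, and "the series" means these few. Any claim that something is new, unique, unknown or untested is made for them only; others in the source may bear on it.

Compound 2 `CCCCCCCCOC(=O)C(O)Cn1cnc2c(N)ncnc21` carries the longest ester chain of the set. Among the compounds with values here, in a functional assay on Vero cells (Chlorocebus sabaeus) for cytotoxicity (on this read-out lower numbers stand for higher toxicity in this test and higher numbers for lower toxicity in this test), compound 2 gives 200 ug/mL, the only number recorded so far. Compound 1 `Nc1ncnc2c1ncn2CC(O)C(=O)OCCO` is its shorter relative. In this assay compound 1 gives > 400 ug/mL, which is a limit of the assay rather than a number. Within the data shown here, the single measured step, an at least 2.0-fold lower number from compound 1 to compound 2 (0.30 log units; that floor lies within the scatter), has to be read against the limit of > 400 ug/mL in this assay, at which 1 of the 2 values shown sits, and so gives only a floor for its size. Compound 3 `CCCCOC(=O)C(O)Cn1cnc2c(N)ncnc21` differs from compound 2 by hydrogen in place of butyl on a saturated chain carbon, four bonds along the chain from an oxygen next to a carbonyl group. The change runs back toward compound 1 along the same chain, so the step from compound 1 to compound 2 is the one that bears on it, and its size sits at the edge of the scatter. A higher number in this assay is therefore expected, possibly again reaching the limit. For compound 3 the expected value is 400 ug/mL, between 200 ug/mL and 800 ug/mL, an estimated step of a 2.0-fold higher number from compound 2 to compound 3 (0.30 log units; within the scatter).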

Compound 3, minimum cytotoxic concentration: 200 ug/mL
Compound 3: the middle estimate sits 2.0-fold (0.30 log units) above what was measured; the range from low to high includes it.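

In this assay, hydrogen in place of butyl, on a saturated chain carbon, four bonds along the chain from an oxygen next to a carbonyl group, leaves no change at the digits printed from compound 2 to compound 3 (within the scatter), so on this read-out the two ester chains are not told apart. Ethyl in place of hydroxy, on a saturated chain carbon, two bonds along the chain from an oxygen next to a carbonyl group, reads as an at least 2.0-fold lower number from compound 1 to compound 3 (0.30 log units; that floor lies within the scatter), and the size of that step stays a floor: the limit of > 400 ug/mL in this assay, at which 1 of the 3 values shown sits. Compound 1 gives > 400 ug/mL, which is a limit and not a number.

Going by these compounds, how far compound 1 truly stands from compound 3 in this assay stays open. Also open, on these data alone, is whether a longer chain, or a chain ending in an amine or a carboxylic acid, would move the value beyond the scatter.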